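Removing the Hydroxy Group from Compound 2

The source may report more compounds than this note shows. Statements on the series, on what has been measured and on what is new or still open speak of the compounds shown alone.

Compound 2 `O=C(CN(c1ncnc2c1ncn2C1CCCCO1)C1CC1)N[C@@H](CO)C(=O)OCc1ccccc1` gives 32.2% in a functional assay on the whole organism (Tail, strain ICR) with Mus musculus as the target, in the tail flick test, with a stated time of 90 min, at a dose of 25 umol/kg by the oral route (on this read-out lower numbers stand for a weaker effect and higher numbers for a stronger effect at the one dose given), the higher of the two numbers in hand, though only a number 8.8 percentage points higher from compound 1 to compound 2 (within the scatter), a gap within the scatter. Compound 1 `C[C@@H](O)[C@H](NC(=O)CN(c1ncnc2c1ncn2C1CCCCO1)C1CC1)C(=O)OCc1ccccc1` gives 23.4% in this assay. Compound 3 `C[C@H](NC(=O)CN(c1ncnc2c1ncn2C1CCCCO1)C1CC1)C(=O)OCc1ccccc1` differs from compound 2 by hydrogen in place of hydroxy on a saturated chain carbon, two bonds along the chain from an amide-type nitrogen and a carbonyl carbon. Among the compounds with values here, no measured step removes a hydroxy group; the one step in hand, a number 8.8 percentage points higher from compound 1 to compound 2 (within the scatter), exchanged a methyl on a saturated chain carbon bound to an oxygen and stayed within the scatter. For compound 3 a step of a number 4.2 percentage points lower from compound 2 to compound 3 (within the scatter) is therefore expected, none beyond the scatter. Compound 3 is estimated at 28%, between 12% and 45%.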

Compound 3, a percentage reported as activity, at one dose (the size of the read-out at that dose, not a potency): 32.1%
Compound 3: the middle estimate sits 4.1 percentage points below what was measured; low and high end bracket the measured number.
By their numbers in this assay, from the lowest: compounds 1, 3 and 2 (each within the scatter of the next).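

Replacing hydroxymethyl with methyl on this saturated chain carbon gives a number 0.1 percentage points lower from compound 2 to compound 3 (within the scatter) in this assay and methyl in place of 1-hydroxyethyl gives a number 8.7 percentage points higher from compound 1 to compound 3 (within the scatter) so neither the hydroxy group nor the whole 1-hydroxyethyl group makes a readable difference here. At this one dose, the three side chains cannot be told apart. No evidence at hand offers an explanation for this result.

Going by these compounds, whether an amine, a carboxylic acid or a longer chain on this carbon would move the number remains open. So does whether these three compounds would separate at another dose or time.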